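Thioether side-chain variation on a shared core: nitrophenyl step

This account rests on a few compounds, and the source may have more. Where it says the series, first, only, none or still open, it means among the compounds named here.

Measured so far in a functional assay on KB cells (Homo sapiens) for inhibition; on this read-out higher numbers stand for weaker inhibition and lower numbers for stronger inhibition:
compound 1, `C#CCSc1nc2cc(Cl)c(Cl)cc2n1C1O[C@H](CO)[C@@H](O)[C@H]1O`: 60000 nM
compound 2, `N#CCSc1nc2cc(Cl)c(Cl)cc2n1C1O[C@H](CO)[C@@H](O)[C@H]1O`: > 100000 nM, which is a limit of the assay and not a number
compound 3, `O=[N+]([O-])c1ccc(CSc2nc3cc(Cl)c(Cl)cc3n2C2O[C@H](CO)[C@@H](O)[C@H]2O)cc1`: 30000 nM

Compound 1 has the highest of the two numbers given; its nearest neighbour is compound 3, and that step, a 2.0-fold lower number from compound 1 to compound 3 (0.30 log units; within the scatter), lies within the usual scatter. Compound 2 sits at a limit, (the limit of > 100000 nM in this assay, at which 1 of the 3 values shown sits). The step of an at least 1.6-fold higher number from compound 1 to compound 2 (0.22 log units; that floor lies within the scatter) reaches only that floor, whereas the step of an at least 3.3-fold lower number from compound 2 to compound 3 (0.52 log units; beyond the scatter) goes beyond the scatter.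

Compound 4, `O=[N+]([O-])c1cccc(CSc2nc3cc(Cl)c(Cl)cc3n2C2O[C@H](CO)[C@@H](O)[C@H]2O)c1`, differs from compound 1 by 3-nitrophenyl in place of ethynyl on a saturated chain carbon bound to a sulfur. The step that bears on it most directly is a 2.0-fold lower number from compound 1 to compound 3 (0.30 log units; within the scatter), where 4-nitrophenyl entered at the same place with a change within the scatter. The step of an at least 3.3-fold lower number from compound 2 to compound 3 (0.52 log units; beyond the scatter) shows the nitrophenyl variant giving a lower number than the cyano one. For compound 4 a step of a 1.7-fold lower number from compound 1 to compound 4 (0.23 log units; within the scatter) is therefore expected, toward a lower number but not clearly beyond the scatter. The estimate for compound 4 in this assay is 35000 nM, with a range from 12000 nM to 100000 nM.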

Compound 4, half-maximal inhibitory concentration: 25000 nM
The estimate for compound 4 lay 1.4-fold (0.15 log units) above the measured number, within the range that was stated.
By their numbers in this assay, from the lowest: compounds 4, 3 and 1 (each within the scatter of the next, the first and the last beyond it). At a limit, above all of these: compound 2.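

In this assay, for the compounds shown here, a 2.4-fold lower number from compound 1 to compound 4 (0.38 log units; beyond the scatter) is the only step starting from compound 1 that lies beyond the scatter, so replacing ethynyl with a nitrophenyl on the saturated chain carbon bound to a sulfur now shows a modest change. The step of a 1.2-fold lower number from compound 3 to compound 4 (0.08 log units; within the scatter) does not separate 3-nitrophenyl from 4-nitrophenyl at this position. Compound 2 is a limit and not a number, which leaves an at least 4.0-fold lower number from compound 2 to compound 4 (0.60 log units; beyond the scatter) as a floor only, though one beyond the scatter: the limit of > 100000 nM in this assay, at which 1 of the 4 values shown sits.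

On these data alone, it remains open whether the step to compound 4 depends on the nitro group or on the phenyl ring alone. An unsubstituted benzyl, or a phenyl ring carrying an amine or a carboxylic acid in place of the nitro group, would address this.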